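This account rests on a few compounds, and the source may have more. Where it says the series, first, only, none or still open, it means among the compounds named here.

Working notes on the series

Three compounds of the series have a number in a physicochemical assay for solubility, read by LC-MS, in phosphate buffer, measured as kinetic solubility, with a stated time of 24 h, at 25 degrees C, at pH 7.4; on this read-out higher numbers stand for higher solubility and lower numbers for lower solubility. Compound 1 `Nc1cc(-c2ccc3c(N)n[nH]c3c2)ncn1` gives 5000 nM. Compound 3 `Nc1nccc(-c2cc3c4c(n[nH]c4c2)Nc2ccncc2O3)n1` gives 10000 nM. Compound 2 `CC(C)(C)Oc1cc(-c2ccnc(N)n2)cc2[nH]nc(N)c12` gives 68000 nM, the highest of the three numbers; its nearest neighbour is compound 3, whose number is lower by more than the scatter, and the furthest is compound 1, lower again by more than the scatter. No pair among these three differs in a single place, so none of the gaps can be tied to one structural change.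

The next compound, compound 4 `Nc1nccc(-c2cc(Oc3ccccc3)c3c(N)n[nH]c3c2)n1`, is not yet measured in this assay. Set against compound 2 it differs in one place: phenyl in place of tert-butyl on an oxygen on an aromatic ring. Within the data shown here, no measured pair carries this change, so the expectation rests on the position of compound 2 alone and on the two lower numbers around it. The step from compound 2 to compound 4 is expected to run downward, beyond the scatter, and to leave compound 4 between the number of compound 3 and that of compound 2, as a 4.5-fold lower number from compound 2 to compound 4 (0.66 log units; beyond the scatter). Compound 4 is estimated at 15000 nM, with a range from 4000 nM to 50000 nM.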

Compound 4, solubility: 117000 nM
Compound 4: middle estimate off by 7.8-fold (0.89 log units), on the low side; the measured number lies above the stated range.
By their numbers in this assay, from the lowest: compounds 1 and 3 (each within the scatter of the next); then compounds 2 and 4 (each within the scatter of the next).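

In this assay, the step reads a 1.7-fold higher number from compound 2 to compound 4 (0.24 log units; within the scatter), so phenyl in place of tert-butyl on an oxygen on an aromatic ring gives no change that can be told from the scatter. Among these compounds, this is the first pair that differs in one place, and it ties a measured step to a single structural change, which the gaps among the earlier compounds could not do: a ring of six aromatic carbons and a branched group of four carbons, neither with hydrogen-bond donors or acceptors nor a net charge, read alike on this oxygen. No available evidence bears on why the two groups read alike.

The compounds shown leave open whether the same holds for groups of another kind on this oxygen, such as an amine-bearing chain, a carboxylic acid or a longer alkyl chain, since both groups compared here are carbon only. They also leave open whether this step would stay within the scatter on a different core, as it rests on a single pair.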